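Sulfonyl for Cyclopropylcarbonyl: Expected Tolerance of Compound 3

The source may report more compounds than this note shows. Statements on the series, on what has been measured and on what is new or still open speak of the compounds shown alone.

Two compounds share a core and were tested in an ADME assay on HepG2 2.2.15 cells (Homo sapiens) for cytotoxicity; a higher number here means that more compound is tolerated, a lower number that less compound is tolerated. Compound 1 `Cc1cc(Br)cc(OC(c2ccc(Cl)cc2)c2cnc(NC(=O)OC(C)(C)C)s2)c1` reached only the assay limit, giving > 50000 nM. Compound 2 `O=C(Nc1ncc(C(Oc2ccc3cc(Br)ccc3c2)c2ccc(Cl)cc2)s1)C1CC1` was reported as "not toxic" (no number reported), without a number, so on the numbers shown compound 2 stands without a value of its own. Among the compounds with values here, the one number in this assay is that of compound 1, which sits at the limit of > 50000 nM in this assay, at which 1 of the 2 values shown sits. Compound 3 `CCc1ccc(S(=O)(=O)Nc2ncc(C(Oc3ccc4cc(Br)ccc4c3)c3ccc(Cl)cc3)s2)cc1` is the next compound in line, differing from compound 2 by (4-ethylphenyl)sulfonyl in place of cyclopropylcarbonyl on a nitrogen on an aromatic ring. The change is (4-ethylphenyl)sulfonyl in place of cyclopropylcarbonyl on a nitrogen on an aromatic ring stated as a swap of groups on the nitrogen of the shared core. Within the data shown here, no measured step exists that would say how such a change moves this assay, so no step beyond the usual scatter is expected in this assay in either direction. Compound 3 is expected to give about 40000 nM, within a range from 10000 nM to 100000 nM.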

Compound 3, half-maximal cytotoxic concentration: > 50000 nM
Compound 3: no number, only a limit; the forecaster's own chance of this, stated with the estimate: 60%; middle value at least 1.2-fold (0.09 log units) away from the limit.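

In this assay compound 3 gives > 50000 nM, which is a limit and not a number. Compound 2 has no number either, so no step can be read between compound 2 and compound 3. The compounds shown leave open how far swapping cyclopropylcarbonyl for (4-ethylphenyl)sulfonyl shifts tolerance, and where the actual values of compound 1 and compound 3 lie: the limit of > 50000 nM in this assay, at which 2 of the 3 values shown sit.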